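This account rests on a few compounds, and the source may have more. Where it says the series, first, only, none or still open, it means among the compounds named here.

Compound 1 `Cc1nc(SCC(=O)Nc2nc(-c3ccc(Cl)cc3)cs2)n(Nc2ccccc2)c1C`: 38900 nM
Compound 2 `Cc1ccc(Nn2c(SCC(=O)Nc3nc(-c4ccccc4)cs3)nc(C)c2C)cc1`: > 100000 nM

Among the compounds with values here, in a functional assay on 786-0 cells (Homo sapiens) for antiproliferative activity, read by sulforhodamine B assay, with a stated time of 48 h (a lower number here means that less compound is tolerated, a higher number that more compound is tolerated), compound 1 gives 38900 nM, the only actual number among the two measured compounds. Compound 2 reaches only a limit of the assay, > 100000 nM, matching (the limit of > 100000 nM in this assay, at which 1 of the 2 values shown sits). Compound 3 `COc1ccc(Nn2c(SCC(=O)Nc3nc(-c4ccc(Cl)cc4)cs3)nc(C)c2C)cc1` differs from compound 1 by methoxy in place of hydrogen on an aromatic carbon. Within the data shown here, no measured pair isolates this change, so the step is expected to be small, at most a modest loss, giving a 1.5-fold higher number from compound 1 to compound 3 (0.19 log units; within the scatter). Compound 3 is therefore estimated at 60000 nM, with a range from 20000 nM to 150000 nM.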

Compound 3, concentration lethal to 50% of the cells: > 100000 nM
Compound 3 ended at the assay's limit (the forecaster's own chance of this, stated with the estimate: 40%); middle value at least 1.6-fold (0.22 log units) from the limit.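

In this assay, within the data shown here, methoxy in place of hydrogen on an aromatic carbon, para to a large group, gives an at least 2.5-fold higher number from compound 1 to compound 3 (0.41 log units; beyond the scatter) and so marks the first step that can be read at this place on the anilino ring. For compound 3 the value > 100000 nM is a limit of the assay and not a number. Going by these compounds, the step is therefore only a lower bound, and its full size stays unknown because compound 3 sits at that ceiling: the limit of > 100000 nM in this assay, at which 2 of the 3 values shown sit.

The compounds shown leave open whether a fluorine, a hydroxyl or an amine at this place would keep the number of compound 1 or shift it.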